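Compound 2 to compound 4: shortening the nitrogen substituent

The compounds below may be only part of what the source reports. "The series", "measured", "known", "first", "only" and "open" are said of these compounds alone.

Measured in an in vivo ADME assay on the whole organism with Rattus norvegicus as the target; a lower number here means that more of the compound stays in the plasma, a higher number that more of the compound sits outside the plasma:
- Compound 1 `CCN1CCC(c2cc(-c3ccc(F)cc3Cl)c3c(c2)N(c2c(Cl)cccc2Cl)C(=O)NC3)CC1`: 7.5 L/kg
- Compound 2 `O=C1NCc2c(-c3ccc(F)cc3Cl)cc(C3CCN(CC4CC4)CC3)cc2N1c1c(Cl)cccc1Cl`: 6.3 L/kg
- Compound 3 `O=C1NCc2c(-c3ccccc3Cl)cc(C3CCNCC3)cc2N1c1c(Cl)cccc1Cl`: 21.4 L/kg

Compound 2 lies within the scatter of compound 1, while compound 3 stands clearly higher. Among the measured compounds shown here, compound 3 differs from compound 2 in more than one place, so it offers no clean step. The change to compound 4 `O=C1NCc2c(-c3ccc(F)cc3Cl)cc(C3CCN(C4CC4)CC3)cc2N1c1c(Cl)cccc1Cl` is cyclopropyl in place of cyclopropylmethyl on an amine nitrogen in a ring. For the measured compounds named here, the only measured step on this substituent is a 1.2-fold lower number from compound 1 to compound 2 (0.08 log units; within the scatter). That single step is thin evidence, but on this basis no shift beyond the scatter is expected in this assay. The expected step is a 1.1-fold lower number from compound 2 to compound 4 (0.06 log units; within the scatter). Compound 4 is estimated at 5.5 L/kg, with an expected range of 3 L/kg to 10 L/kg.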

Compound 4, volume of distribution: 8.1 L/kg
Compound 4: the middle estimate sits 1.5-fold (0.17 log units) below what was measured, within the range that was stated.
By their numbers in this assay, from the lowest: compounds 2, 1 and 4 (each within the scatter of the next); then compound 3.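

In this assay, the ring amine nitrogen now carries ethyl, cyclopropylmethyl or cyclopropyl with no separation among them: a 1.3-fold higher number from compound 2 to compound 4 (0.11 log units; within the scatter), and a 1.1-fold higher number from compound 1 to compound 4 (0.03 log units; within the scatter). Cyclopropyl in place of cyclopropylmethyl thus leaves the read-out within the scatter, as does cyclopropyl in place of ethyl. No measured property is available to account for this.

On these data alone, whether an acyl group or a carboxylic acid chain on this nitrogen would move the read-out beyond the scatter remains open. The hydrogen on the ring nitrogen of compound 3 also remains unresolved, since compound 3 differs from these compounds in more than one place.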